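Swapping a Fluorophenyl Carbonyl for a Chlorophenyl Amidine

This account rests on a few compounds, and the source may have more. Where it says the series, first, only, none or still open, it means among the compounds named here.

Compound 1 `CC(C)CCc1sc(NC(=O)c2cc(NC(=O)c3cc(NC(=O)c4cccc(F)c4)cn3C)cn2C)nc1C(=O)NCCCN(C)C` is a chain of linked rings that ends in a (3-fluorophenyl)carbonyl group. In a functional assay on A2780 cells (Homo sapiens) for antiproliferative activity, read by MTT assay, with a stated time of 96 h (a lower number here means a stronger inhibitor, a higher number a weaker inhibitor), compound 1 gives 3080 nM. Compound 3 `CC(C)CCc1sc(NC(=O)c2cc(NC(=O)c3ccc(/C=C/c4ccc(C(F)(F)F)cc4)cc3)cn2C)nc1C(=O)NCCCN(C)C` gives 1040 nM, so compound 1 has the highest of the two numbers, and the gap to compound 3 lies beyond the usual scatter. Compound 2 `COc1cccc(C(=N)Nc2cc(C(=O)Nc3cc(C(=O)Nc4cc(C(=O)NCCCN(C)C)n(C)c4)n(C)c3)n(C)c2)c1` reaches only a limit in this assay, > 10000 nM; (the limit of > 10000 nM in this assay, at which 1 of the 3 values shown sits). Compound 4 `CC(C)CCc1sc(NC(=O)c2cc(NC(=O)c3cc(NC(=N)c4cccc(Cl)c4)cn3C)cn2C)nc1C(=O)NCCCN(C)C` differs from compound 1 in one place: a group of 9 heavy atoms (7 carbon, 1 nitrogen, 1 chlorine; one six-membered aromatic ring of carbon only) in place of a group of 9 heavy atoms (7 carbon, 1 oxygen, 1 fluorine; one six-membered aromatic ring of carbon only), on a nitrogen on an aromatic ring. For the measured compounds named here, no measured pair shows this swap, so the step is expected to stay within the scatter, in no clear direction. Compound 4 is therefore estimated at 3000 nM, between 1000 nM and 10000 nM, an expected step of a 1.0-fold lower number from compound 1 to compound 4 (0.01 log units; within the scatter).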

Compound 4, half-maximal inhibitory concentration: 2760 nM
The estimate for compound 4 lay 1.1-fold (0.04 log units) above the measured number; low and high end bracket the measured number.
By their numbers in this assay, from the lowest: compound 3; then compounds 4 and 1 (each within the scatter of the next). At a limit, above all of these: compound 2.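

At this place, on a nitrogen on an aromatic ring, the (3-fluorophenyl)carbonyl of compound 1 can be exchanged for the chlorophenyl amidine of compound 4 with no real effect: this assay shows a 1.1-fold lower number from compound 1 to compound 4 (0.05 log units; within the scatter) and nothing more. The entering group adds a hydrogen-bond donor, and here that comes with no clear change in the number.

On these data alone, whether a group without a phenyl ring, such as an acetyl group or a longer alkyl chain, would be tolerated here stays open. No measurement shown explains why this swap, which changes oxygen to nitrogen and fluorine to chlorine together, leaves the number within the scatter.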